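The source may report more compounds than this note shows. Statements on the series, on what has been measured and on what is new or still open speak of the compounds shown alone.

Measured compounds:
- compound 1 `C=C(Br)C(=O)Nc1cccc(-c2cn3nc(-c4ccccc4)sc3n2)c1`: 1400 nM
- compound 2 `Nc1cccc(-c2cn3c(-c4ccc(Cl)cc4)csc3n2)c1`: 17000 nM

Two compounds carry a number in a functional assay on HeLa cells (Homo sapiens) for inhibition, read by cell counting, with a stated time of 4 days; on this read-out higher numbers stand for weaker inhibition and lower numbers for stronger inhibition. Compound 1 `C=C(Br)C(=O)Nc1cccc(-c2cn3nc(-c4ccccc4)sc3n2)c1` gives 1400 nM, the lower of the two numbers. Compound 2 `Nc1cccc(-c2cn3c(-c4ccc(Cl)cc4)csc3n2)c1` gives 17000 nM, a number that lies beyond the scatter above that of compound 1. Among the measured compounds shown here, the two structures differ in several places at once, so their two values show only that compound 1 is the stronger inhibitor of the pair, and nothing about any single change.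

Compound 3 `C=C(Br)C(=O)Nc1cccc(-c2cn3nc(-c4cccs4)sc3n2)c1` has not yet been measured in this assay. It differs from compound 1 in one place: thiophen-2-yl in place of phenyl on an aromatic carbon. For the measured compounds named here, no step between two measured compounds in this set isolates this change, so the size of the step must be judged from the change alone. An exchange of phenyl for thiophen-2-yl on an aromatic carbon is a small one in size and shape, and no direction is suggested by the data. The step from compound 1 to compound 3 is therefore expected to stay within the scatter, a 1.1-fold lower number from compound 1 to compound 3 (0.03 log units; within the scatter). Compound 3 is estimated at 1300 nM, with a range from 450 nM to 4000 nM.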

Compound 3, half-maximal inhibitory concentration: 670 nM
Compound 3: middle estimate off by 1.9-fold (0.29 log units), on the high side; the measured number falls inside the stated range.
By their numbers in this assay, from the lowest: compound 3; then compound 1; then compound 2.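

In this assay, among the compounds shown here, thiophen-2-yl in place of phenyl on the aromatic carbon of the five-membered aromatic ring with 2 nitrogen and 1 sulfur gives a 2.1-fold lower number from compound 1 to compound 3 (0.32 log units; beyond the scatter) as a modest step, and this is the first step in the set that isolates a single place. It shows that this position does not demand phenyl: a five-membered aromatic ring with 1 hetero atom can stand there with inhibition retained and somewhat stronger, on the evidence of this one pair alone. Nothing measured on these compounds speaks to the cause of this step.

The compounds shown leave open how other groups on this carbon would read, such as furan-2-yl, pyridin-3-yl, an amine or a carboxylic acid, and so whether the step belongs to thiophen-2-yl in particular or to aromatic rings of this size more broadly. They also leave open whether the same exchange would give a step of like size and direction if the bromoacrylamide group of compound 1 were replaced by a plain amine.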